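Swapping Methyl for Chlorine on a Benzyl Thioether

The source may report more compounds than this note shows. Statements on the series, on what has been measured and on what is new or still open speak of the compounds shown alone.

Of the compounds shown here, three that share one core have been tested in a functional assay on SW 1116 cells (Homo sapiens) for antiproliferative activity, read by MTT assay, with a stated time of 48 h; a higher number here means a weaker inhibitor, a lower number a stronger inhibitor. Compound 1 `Fc1ccc(CSc2nnc(-c3ccc4c(c3)OCCO4)o2)cc1` gives 21600 nM. Compound 2 `O=[N+]([O-])c1cccc(CSc2nnc(-c3ccc4c(c3)OCCO4)o2)c1` gives 30100 nM, and compound 3 `Cc1ccccc1CSc1nnc(-c2ccc3c(c2)OCCO3)o1` gives 23900 nM. Compound 3 thus holds the second highest of the three numbers, yet all three lie within the usual scatter of one another, so none of them can be called a stronger or weaker inhibitor than the others. Among the compounds with values here, the only step that joins two measured compounds differing in one place, 4-fluorophenyl in place of 2-methylphenyl on a saturated chain carbon bound to a sulfur, shows a 1.1-fold higher number from compound 1 to compound 3 (0.04 log units; within the scatter).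

Compound 4 `Clc1ccccc1CSc1nnc(-c2ccc3c(c2)OCCO3)o1` has not yet been measured. It differs from compound 3 in one place: chloro in place of methyl on an aromatic carbon. Within the data shown here, no measured step alters a group on this aromatic carbon, so the only guide is that every variation of the benzyl part seen so far, in compounds 1, 2 and 3, left the number within the scatter. The same is expected here: in this assay compound 4 is expected to give 24000 nM, with a likely range from 9000 nM to 60000 nM. This estimate corresponds to an expected 1.0-fold higher number from compound 3 to compound 4 (0.00 log units; within the scatter).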

Compound 4, half-maximal inhibitory concentration: 29500 nM
For compound 4 the middle estimate is 1.2-fold (0.09 log units) below the measured one; the measured number falls inside the stated range.
By their numbers in this assay, from the lowest: compounds 1, 3, 4 and 2 (each within the scatter of the next).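

In this assay, within the data shown here, chloro in place of methyl on an aromatic carbon, ortho to a large group, gives a 1.2-fold higher number from compound 3 to compound 4 (0.09 log units; within the scatter) and is the first reading at this position, where the two groups cannot be told apart. The wider change of 4-fluorophenyl to 2-chlorophenyl on a saturated chain carbon bound to a sulfur gives a 1.4-fold higher number from compound 1 to compound 4 (0.14 log units; within the scatter) and also cannot be told apart, so neither step reveals a preference among these groups on the benzyl part. No supporting measurement bears on this result, so nothing can be said about what lies behind it.

It remains open whether any group at this position can carry the number beyond the usual scatter, since an amine, a carboxylic acid or a methoxy group on this aromatic carbon has no reading among these compounds. Also open, as far as these compounds go, is how a longer chain between the sulfur and the aromatic ring would read in this assay, and whether changes to the shared core would matter more than changes to the benzyl part.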